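The source may hold more compounds than are shown below. What is called first, only, known or untested is meant among the compounds shown, and "the series" means these compounds.

Measured so far in this study:

Compound 1, `COc1cc(/C=C/C(=O)C2=C(/C=C/c3ccc(O)c(OC)c3)NC(=O)NC2c2ccc(N(C)C)cc2)ccc1O`: 69.9%
Compound 2, `COc1cc(/C=C/C(=O)C2=C(/C=C/c3ccc(O)c(OC)c3)NC(=O)NC2c2c(Cl)cccc2Cl)ccc1O`: 20%
Compound 3, `COc1cc(/C=C/C(=O)C2=C(/C=C/c3ccc(O)c(OC)c3)NC(=S)NC2c2ccc(N(C)C)cc2)ccc1O`: 59%

All three numbers come from a functional assay, with a stated time of 20 min, tested at 10 uM; a higher number here means a stronger effect of the compound at the concentration tested, a lower number a weaker effect. Compound 1 and compound 3 share most of their structure, but how their two cores differ is not broken down here; in this assay compound 3 sits somewhat lower than compound 1, and compound 2 lies far below both.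

Compound 2 arises from compound 1 by a single change: 2,6-dichlorophenyl in place of 4-(dimethylamino)phenyl on a saturated ring carbon. That change made a large step downward: a number 49.9 percentage points lower from compound 1 to compound 2 (beyond the scatter).

Compound 4, `COc1cc(/C=C/C(=O)C2=C(/C=C/c3ccc(O)c(OC)c3)NC(=S)NC2c2c(Cl)cccc2Cl)ccc1O`, has not yet been measured. It arises from compound 3 by the same change at the same place: 2,6-dichlorophenyl in place of 4-(dimethylamino)phenyl on a saturated ring carbon. If the change behaves as it did before, a drop of similar size is expected from compound 3 to compound 4, a number 47 percentage points lower from compound 3 to compound 4 (beyond the scatter), an expectation that rests on a number 49.9 percentage points lower from compound 1 to compound 2 (beyond the scatter) seen earlier. Compound 4 is therefore estimated to give 12% in this assay. That estimate is expected to fall between 0% and 30%.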

Compound 4, a percentage reported as activity, at one concentration (the size of the read-out at that concentration, not a potency): 20.2%
Beside the measured number, compound 4's estimate is 8.2 percentage points below it; the measured number falls inside the stated range.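

In this assay, placing 2,6-dichlorophenyl where 4-(dimethylamino)phenyl stood on the saturated ring carbon again gave a large fall, a number 38.8 percentage points lower from compound 3 to compound 4 (beyond the scatter). Set beside the earlier case, the two steps cannot be told apart: the same change on two cores in this assay, a number 49.9 percentage points lower (beyond the scatter) from compound 1 to compound 2 and a number 38.8 percentage points lower (beyond the scatter) from compound 3 to compound 4, 11.1 percentage points apart, within the scatter of two such steps. Among these compounds, the change therefore carries over between these two cores, with the same direction and a similar size, but this rests on only two pairs of compounds, so it says nothing about other cores and does not explain why the read-out falls.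

The compounds shown hold only two groups on this ring carbon, so it remains open whether the fall comes from losing 4-(dimethylamino)phenyl or from gaining 2,6-dichlorophenyl, and an unsubstituted phenyl or a 4-chlorophenyl in the same place could help separate the two. Also open, as far as these compounds go, is whether the same pattern of stronger and weaker effects would hold at other concentrations: each number here gives the size of the effect at a single concentration.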